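Compound 3: morpholin-4-yl in place of the anilide

The compounds below may be only part of what the source reports. "The series", "measured", "known", "first", "only" and "open" are said of these compounds alone.

Compound 1 `N#C/C(=C\c1cc(O)c(O)c([N+](=O)[O-])c1)C(=O)Nc1cccc(Cl)c1` is the reference point. In a functional assay on KB cells (Homo sapiens) for antiproliferative activity, read by MTT assay (a higher number here means a weaker inhibitor, a lower number a stronger inhibitor), compound 1 gives 72.7 ug/mL. Compound 2 `COc1cc(/C=C(\C#N)C(=O)Nc2cccc(Cl)c2)cc([N+](=O)[O-])c1O` carries methyl in place of hydrogen on an oxygen on an aromatic ring, and compound 2 gives 56.6 ug/mL; the step of a 1.3-fold lower number from compound 1 to compound 2 (0.11 log units; within the scatter) lies within the scatter, so the two numbers stand level. Compound 3 `N#C/C(=C\c1cc(O)c(O)c([N+](=O)[O-])c1)C(=O)N1CCOCC1` differs from compound 1 at the carbonyl carbon: morpholin-4-yl in place of (3-chlorophenyl)amino on a carbonyl carbon. Within the data shown here, no measured step touches this carbonyl substituent; the single known step concerns an oxygen on an aromatic ring and says nothing about the amide. Among the measured compounds shown here, the only guidance is that the one change tried so far moved the number little. A step of a 1.2-fold higher number from compound 1 to compound 3 (0.09 log units; within the scatter) is therefore expected, carrying wide uncertainty in both directions. Compound 3 is expected to give 90 ug/mL, with a range from 35 ug/mL to 230 ug/mL.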

Compound 3, half-maximal inhibitory concentration: > 100 ug/mL
Compound 3 ended at the assay's limit (the forecaster's own chance of this, stated with the estimate: 15%); middle value at least 1.1-fold (0.04 log units) from the limit.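

The carbonyl carbon is a position the earlier step did not reach: morpholin-4-yl in place of (3-chlorophenyl)amino gives an at least 1.3-fold higher number from compound 1 to compound 3 (0.13 log units; that floor lies within the scatter). In this assay compound 3 stands at a limit of the assay and not at a number: the limit of > 100 ug/mL in this assay, at which 1 of the 3 values shown sits. The change gives no sign of a stronger inhibitor, but only a floor is known and that floor lies within the scatter, leaving a real weakening neither established nor excluded.

One change removed both the aromatic ring and the amide hydrogen of the (3-chlorophenyl)amino group, and the two cannot be told apart here. Open too, on these data alone, is how the number responds on this carbonyl carbon to piperidin-1-yl, which lacks the ring oxygen of morpholin-4-yl, or to a phenylamino group without the chlorine.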